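Adding a Hydroxy Group to the Ring of Compound 1

A few compounds are considered here, and "the series" means these few. Any claim that something is new, unique, unknown or untested is made for them only; others in the source may bear on it.

Of the compounds shown here, three have been measured in a functional assay on FL5.12 cells (Mus musculus), read by flow cytometry, with a stated time of 3 h, tested at 2.5 uM; on this read-out higher numbers stand for a stronger effect at the one concentration tested and lower numbers for a weaker effect. Compound 1 `CCCCCCCCc1ccc(C(=O)C[C@@H]2CCCN2)cc1` gives 28%. Compound 2 `CCCCCCCCc1ccc(CC[C@@H]2CCCN2)cc1` gives 41%, and compound 3 `CCCCCCCCc1ccc(C(C[C@@H]2CCCN2)OC)cc1` gives 16%. Compound 1 thus stands second highest of the three, beyond the scatter below compound 2 and above compound 3.

Compound 4 `CCCCCCCCc1ccc(C(=O)C[C@@H]2C[C@@H](O)CN2)cc1` differs from compound 1 by hydroxy in place of hydrogen on a saturated ring carbon. Among the measured compounds shown here, the only measured step also introduces an oxygen-containing group, a methoxy, but on a saturated chain carbon rather than on the ring: a number 25 percentage points lower from compound 2 to compound 3 (beyond the scatter). That step bears only loosely on the present change, so a small decrease or no step beyond the scatter is expected. The expected step is a number 6 percentage points lower from compound 1 to compound 4 (within the scatter). Compound 4 is estimated at 22%, between 8% and 38%.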

Compound 4, a percentage reported as activity, at one concentration (the size of the read-out at that concentration, not a potency): 22%
Estimate against measurement, compound 4: no gap at the digits printed, within the range that was stated.
By their numbers in this assay, from the lowest: compounds 3, 4 and 1 (each within the scatter of the next, the first and the last beyond it); then compound 2.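

In this assay, hydroxy in place of hydrogen on this saturated ring carbon, two ring bonds from the ring nitrogen, gives a number 6 percentage points lower from compound 1 to compound 4 (within the scatter). This is the first change shown on the ring itself, and it shows that this position can carry a hydroxy group with no step beyond the scatter. Nothing measured here gives a reason for this result.

From the compounds shown here alone, whether an amine or a carboxylic acid on this same ring carbon would also leave the read-out within the scatter remains open. So does the effect of the same hydroxy group on compound 2.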